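Furan position swap on the dihydropyrimidinone series

This account rests on a few compounds, and the source may have more. Where it says the series, first, only, none or still open, it means among the compounds named here.

Of the compounds shown here, three of the shared core have been measured. Compound 1 `CCCOC(=O)C1=C(C)NC(=O)NC1c1ccoc1` gives 11% in an assay on membranes from HeLa cells for displacement of a labelled ligand from adenosine receptor A3 (Homo sapiens), read by scintillation counting, with a stated time of 180 min, tested at 1 uM; on this read-out lower numbers stand for less inhibition and higher numbers for more inhibition at the one concentration tested (going by the name of the read-out). Compound 2 `CC1=C(C(=O)OC(C)(C)C)C(c2ccoc2)NC(=O)N1` gives 2% in this assay, and compound 3 `CC1=C(C(=O)C2CC2)C(c2ccco2)NC(=O)N1` gives 7% in this assay. Within the data shown here, the one single-site step measured so far, a number 9 percentage points lower from compound 1 to compound 2 (within the scatter), concerns the ester alkyl group alone. Compound 3 sits among the three numbers with compound 1 as its nearest neighbour and compound 2 as its furthest, both gaps lying within the scatter, so nothing in this set separates the three.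

Compound 4 `CC1=C(C(=O)C2CC2)C(c2ccoc2)NC(=O)N1` is not yet measured. It differs from compound 3 by furan-3-yl in place of furan-2-yl on a saturated ring carbon. Among the measured compounds shown here, compound 1 and compound 2 already carry furan-3-yl, while compound 3 carries furan-2-yl, yet their values in this assay all lie within the scatter of one another, and no measured step follows this change in isolation. The step of a number 9 percentage points lower from compound 1 to compound 2 (within the scatter) bears on a different position and offers no guidance here. The step of a number 1 percentage points higher from compound 3 to compound 4 (within the scatter) is therefore expected to stay within the scatter, with no direction favoured. Compound 4 is estimated at 8% in this assay, with a range from 0% to 20%.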

Compound 4, a percentage reported as inhibition, at one concentration (the size of the read-out at that concentration, not a potency): 16%
Estimate against measurement, compound 4: 8 percentage points below, and the stated range covers the measured number.
By their numbers in this assay, from the lowest: compounds 2, 3, 1 and 4 (each within the scatter of the next, the first and the last beyond it).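

Working notes on the furan swap: in this assay the swap now has a step of its own, and a number 9 percentage points higher from compound 3 to compound 4 (within the scatter) shows that furan-3-yl in place of furan-2-yl on a saturated ring carbon, with the cyclopropylcarbonyl group held constant, cannot be told apart from the usual scatter, so no preference between the two furan attachments can be stated. Among these compounds, the new compound also gives the first step to clear the scatter, at the carbonyl carbon rather than at the furan: a number 14 percentage points higher from compound 2 to compound 4 (beyond the scatter) separates cyclopropyl from tert-butoxy, whereas a number 5 percentage points higher from compound 1 to compound 4 (within the scatter) leaves cyclopropyl and propoxy unseparated, so the gain holds against one ester alkyl group and not against the other. The data at hand hold nothing that would account for either step.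

Still open, going by these compounds, is whether the furan swap behaves the same way when an ester rather than cyclopropyl sits on the carbonyl carbon, since the series shows that change in one setting only. Also open, on these data alone, is whether a cyclobutyl group, a longer chain or an amine on the carbonyl carbon would move the read-out clearly beyond the scatter, and whether any such difference would hold as a potency rather than at one concentration.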